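Swapping the side group of compound 2 for a ring

A few compounds are considered here, and "the series" means these few. Any claim that something is new, unique, unknown or untested is made for them only; others in the source may bear on it.

In a functional assay on HT-29 cells (Homo sapiens) for inhibition, read by sulforhodamine B assay, with a stated time of 48 h (on this read-out lower numbers stand for stronger inhibition and higher numbers for weaker inhibition), compound 1 `CCNC(=O)Nc1ccc(/C=C\c2cc(OC)c(OC)c(OC)c2)cc1` gives 21000 nM and compound 2 `CCNC(=O)Nc1ccc(/C=C/c2cc(OC)c(OC)c(OC)c2)cc1` gives 12000 nM. On these numbers compound 2 cannot be told apart from compound 1. Among the measured compounds shown here, the only measured step, a 1.8-fold lower number from compound 1 to compound 2 (0.24 log units; within the scatter), stays within the scatter and concerns (the fact that compounds 1 and 2 differ only in the configuration as drawn), not the group that changes next. Compound 3 `COc1cc(/C=C/c2ccc(N3CCNC3=O)cc2)cc(OC)c1OC` carries 2-oxoimidazolidin-1-yl in place of (ethylcarbamoyl)amino on an aromatic carbon. For the measured compounds named here, no measured step touches this group, so the expectation rests on the level of compound 2 at 12000 nM, and no step beyond the scatter is expected in this assay. The estimated change is a 1.2-fold higher number from compound 2 to compound 3 (0.07 log units; within the scatter). The expected value for compound 3 is 14000 nM, with an estimated range from 4000 nM to 50000 nM.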

Compound 3, half-maximal inhibitory concentration: 370 nM
Beside the measured number, compound 3's estimate is 38-fold (1.58 log units) above it, outside the stated range (below it).
By their numbers in this assay, from the lowest: compound 3; then compounds 2 and 1 (each within the scatter of the next).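

In this assay, among the compounds shown here, replacing the open (ethylcarbamoyl)amino group with the 2-oxoimidazolidin-1-yl ring gives a 32-fold lower number from compound 2 to compound 3 (1.51 log units; beyond the scatter), which shows that this place on the aromatic carbon, para to a large group, responds strongly to the group it carries, whereas the only earlier step, a 1.8-fold lower number from compound 1 to compound 2 (0.24 log units; within the scatter), stayed within the scatter. The two groups have the same heavy atoms by count, so what the counts separate is the five-membered non-aromatic ring and the hydrogen-bond donors, with one fewer donor in compound 3 than in compound 2. Nothing available here explains why the step is so large.

The compounds shown do not separate the effect of the ring from that of the lost donor. On these data alone, how a methyl group on the ring nitrogen that still carries hydrogen, or a pyrrolidin-1-yl ring with no carbonyl, would behave at this place remains open.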